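A few compounds are considered here, and "the series" means these few. Any claim that something is new, unique, unknown or untested is made for them only; others in the source may bear on it.

Measured compounds in a functional assay on MCF7 cells (Homo sapiens) for antiproliferative activity, read by MTT assay, with a stated time of 48 h, tested at 25 uM; on this read-out higher numbers stand for a weaker effect at the one concentration tested and lower numbers for a stronger effect:
compound 1 `OC(CCn1nc2c(Br)c(Br)c(Br)c(Br)c2n1)c1cccc(Br)c1`: 106%
compound 2 `OC(CCn1nc2c(Br)c(Br)c(Br)c(Br)c2n1)c1ccc(Br)cc1`: 105%

Among the compounds with values here, compound 2 gives the lowest of the two numbers in this assay; the nearest is compound 1, and the one measured step, a number 1 percentage points lower from compound 1 to compound 2 (within the scatter), lies within the scatter. Compound 3 `OC(CCn1nc2c(Br)c(Br)c(Br)c(Br)c2n1)c1ccc(Cl)cc1` differs from compound 2 by chloro in place of bromo on an aromatic carbon. Within the data shown here, no measured step bears on a bromo-to-chloro exchange, and the only step in hand concerns a different change and was within the scatter. A step of no more than the scatter is therefore expected, a number 2 percentage points lower from compound 2 to compound 3 (within the scatter). For compound 3 the estimate in this assay is 103%, with a range from 88% to 115%.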

Compound 3, a percentage reported as activity, at one concentration (the size of the read-out at that concentration, not a potency): 92%
Estimate against measurement, compound 3: 11 percentage points above, within the range that was stated.
By their numbers in this assay, from the lowest: compound 3; then compounds 2 and 1 (each within the scatter of the next).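

In this assay, within the data shown here, chloro in place of bromo, on an aromatic carbon para to a large group, gives a number 13 percentage points lower from compound 2 to compound 3 (beyond the scatter) and so is the first change to pass the scatter. The 4-chlorophenyl also separates from the 3-bromophenyl, with a number 14 percentage points lower from compound 1 to compound 3 (beyond the scatter) against a bromo shift that stayed within the scatter. Nothing at hand accounts for the halogen effect.

Open, going by these compounds, is whether fluoro, methoxy or an unsubstituted phenyl at this place would continue the step. Also open, on these data alone, is how a 3-chlorophenyl would compare with the 4-chlorophenyl.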